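The source may hold more compounds than are shown below. What is called first, only, known or untested is meant among the compounds shown, and "the series" means these compounds.

Compound 2, `CC(C(=O)NCc1ccc(C(F)(F)F)nc1Nc1ccccc1)c1ccc(NS(C)(=O)=O)c(F)c1`, carries an anilino group on the shared core. Among the measured compounds shown here, in a functional assay on CHO-K1 cells for antagonist activity at transient receptor potential cation channel subfamily V member 1 (Homo sapiens), read by FLIPR (a higher number here means a weaker inhibitor, a lower number a stronger inhibitor), compound 2 gives 59.6 nM, the highest of the two numbers measured so far. For the measured compounds named here, its nearest neighbour is compound 1, `CCCCNc1nc(C(F)(F)F)ccc1CNC(=O)C(C)c1ccc(NS(C)(=O)=O)c(F)c1`, which in this assay gives 9.1 nM; the single measured step between them, a 6.5-fold higher number from compound 1 to compound 2 (0.82 log units; beyond the scatter), describes the exchange of the butyl for the phenyl on the ring nitrogen. Compound 3, `CC(C(=O)NCc1ccc(C(F)(F)F)nc1Nc1ccc(F)cc1)c1ccc(NS(C)(=O)=O)c(F)c1`, differs from compound 2 in one place only: fluoro in place of hydrogen on an aromatic carbon. Going by the values given here, no measured step bears directly on this change. The step of a 6.5-fold higher number from compound 1 to compound 2 (0.82 log units; beyond the scatter) concerns a different part of the molecule and gives no guide to what a fluoro on the phenyl will do. With nothing in the data pointing either way, the outcome expected for compound 3 in this assay is a step no larger than the scatter, a 1.2-fold lower number from compound 2 to compound 3 (0.08 log units; within the scatter), in no decided direction. The estimate for compound 3 in this assay is therefore 50 nM, with a range from 20 nM to 150 nM.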

Compound 3, inhibition constant: 39.2 nM
Compound 3: the middle estimate sits 1.3-fold (0.11 log units) above what was measured; low and high end bracket the measured number.
By their numbers in this assay, from the lowest: compound 1; then compounds 3 and 2 (each within the scatter of the next).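

In this assay, placing a fluoro on this aromatic carbon, para to a large group, gives a 1.5-fold lower number from compound 2 to compound 3 (0.18 log units; within the scatter) and so shows that this position of the phenyl accepts the fluoro with no change that can be told from the scatter. The replacement of butyl on the ring nitrogen still costs potency once the fluoro is present, as a 4.3-fold higher number from compound 1 to compound 3 (0.63 log units; beyond the scatter) shows, so the 4-fluorophenyl, like the plain phenyl, remains on the weaker side of the butyl in this series of three compounds. The material at hand offers no measurement that accounts for either step.

The compounds shown leave open whether a chloro, a methoxy or a nitrile at the same aromatic carbon would give a step beyond the scatter, and whether a fluoro elsewhere on that ring would behave as this one does. They also leave open whether a cyclohexyl, a benzyl or a shorter alkyl chain on the ring nitrogen would stand closer to the butyl than the aromatic groups do.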